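The compounds below may be only part of what the source reports. "The series", "measured", "known", "first", "only" and "open" are said of these compounds alone.

Of the compounds shown here, two with a shared core have been measured in a functional assay on A549 cells (Homo sapiens) for cytotoxicity, read by MTT assay, with a stated time of 48 h; a lower number here means a stronger inhibitor, a higher number a weaker inhibitor. Compound 1 `COc1cc(-n2nnnc2-c2ccc(OCC3CC(c4cccc(Cl)c4)=NO3)c(N)c2)cc(OC)c1OC` carries a 3-chlorophenyl group on a carbon with a double bond to nitrogen, and in this assay compound 1 gives 1340 nM. Compound 2 `COc1ccc(OC)c(C2=NOC(COc3ccc(-c4nnnn4-c4cc(OC)c(OC)c(OC)c4)cc3N)C2)c1` differs from it only in that place, where a 2,5-dimethoxyphenyl group sits instead; in this assay compound 2 gives 1930 nM. The step of a 1.4-fold higher number from compound 1 to compound 2 (0.16 log units; within the scatter) shows that exchanging the aryl group there did not move the number beyond the scatter. Of the two numbers, compound 1 has the lower one, but its gap to compound 2 is within the scatter, so the two cannot be ordered.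

Compound 3 `COc1ccc(C2=NOC(COc3ccc(-c4nnnn4-c4cc(OC)c(OC)c(OC)c4)cc3N)C2)cc1[N+](=O)[O-]` has not yet been measured. It differs from compound 1 in the same place: 4-methoxy-3-nitrophenyl in place of 3-chlorophenyl on a carbon with a double bond to nitrogen. Going by the values given here, the only step that bears on this change is the one from compound 1 to compound 2, which stayed within the scatter, so no step beyond the scatter is expected here in either direction. On that basis the estimated step is a 1.3-fold higher number from compound 1 to compound 3 (0.10 log units; within the scatter). In this assay compound 3 is expected to give about 1700 nM, within a range from 800 nM to 3600 nM.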

Compound 3, half-maximal inhibitory concentration: 2220 nM
The estimate for compound 3 lay 1.3-fold (0.12 log units) below the measured number; measured number inside the range.
By their numbers in this assay, from the lowest: compounds 1, 2 and 3 (each within the scatter of the next).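

In this assay, a third aryl group at this place, on a carbon with a double bond to nitrogen of the five-membered ring, again leaves the number within the scatter: exchanging 3-chlorophenyl for 4-methoxy-3-nitrophenyl gives a 1.7-fold higher number from compound 1 to compound 3 (0.22 log units; within the scatter) and exchanging 2,5-dimethoxyphenyl for it gives a 1.2-fold higher number from compound 2 to compound 3 (0.06 log units; within the scatter). Across these three compounds, then, the position has held a chlorine-bearing ring, a ring with two methoxy groups and now a ring with a methoxy and a nitro group, and no step between any two of them lies beyond the scatter, so a nitro group on this ring also fails to separate the compounds in this assay. Nothing available here gives a reason for these numbers.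

Going by these compounds, what stays open is whether a group of a different kind at this place, such as a plain methyl, a cyclohexyl ring, or a phenyl ring carrying an amine or a carboxylic acid, would move the number beyond the scatter. Going by these compounds alone, it also stays open whether a change elsewhere on the shared core would do so, as every step so far lies at this one place.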